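Chloro for methyl on a phenoxy ring: cytotoxicity

This account rests on a few compounds, and the source may have more. Where it says the series, first, only, none or still open, it means among the compounds named here.

Measured compounds:
compound 1, `Cc1ccc(-c2csc(NC(=O)COc3ccccc3C(C)C)n2)cc1`: 44700 nM
compound 2, `CC(C)c1ccccc1OCC(=O)Nc1nc(-c2ccc(Cl)cc2)cs1`: 17100 nM
compound 3, `Cc1ccc(OCC(=O)Nc2nc(-c3ccc(C)cc3)cs2)cc1`: 48800 nM

These values come from a functional assay on A549 cells (Homo sapiens) for cytotoxicity, read by trypan blue exclusion, with a stated time of 48 h; on this read-out higher numbers stand for weaker inhibition and lower numbers for stronger inhibition. Compound 1 and compound 3 share a common core, but the difference between the two cores is not broken down here. From compound 1 to compound 2 one change, (chloro in place of methyl on an aromatic carbon), gave a 2.6-fold lower number from compound 1 to compound 2 (0.42 log units; beyond the scatter).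

Compound 4, `Cc1ccc(-c2csc(NC(=O)COc3ccc(Cl)cc3)n2)cc1`, is reached from compound 3 by the same change, (chloro in place of methyl on an aromatic carbon), though cut one bond further out it reads 4-methylphenoxy to 4-chlorophenoxy rather than 4-methylphenyl to 4-chlorophenyl. A similar direction is expected, but a smaller step, because a 2.6-fold lower number from compound 1 to compound 2 (0.42 log units; beyond the scatter) was seen on the other ring. The expected step in this assay is a 1.5-fold lower number from compound 3 to compound 4 (0.17 log units; within the scatter). Compound 4 is estimated at 33000 nM, between 15000 nM and 70000 nM.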

Compound 4, half-maximal inhibitory concentration: 44700 nM
The estimate for compound 4 lay 1.4-fold (0.13 log units) below the measured number; the range from low to high includes it.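

In this assay, chloro in place of methyl on the phenoxy ring gave a 1.1-fold lower number from compound 3 to compound 4 (0.04 log units; within the scatter), so on this core the swap shows no clear effect. The step on the other core cannot be told apart from this one: the same change on two cores in this assay, a 2.6-fold lower number (0.42 log units; beyond the scatter) from compound 1 to compound 2 and a 1.1-fold lower number (0.04 log units; within the scatter) from compound 3 to compound 4, 2.4-fold (0.38 log units) apart, within the scatter of two such steps. The change may therefore carry over between the two cores, but two steps neither prove that it does nor show how large its effect would be on a further core.

The compounds shown leave open whether a fluoro, a methoxy or a trifluoromethyl group in this place would read differently from methyl and chloro. They also leave open what an amine or a carboxylic acid there would do.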